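A Single Ester Cut Back to Its Acid

The compounds below may be only part of what the source reports. "The series", "measured", "known", "first", "only" and "open" are said of these compounds alone.

Compound 1 `CCOC(=O)C1=Cc2ccccc2OC1(OCc1cc(-c2ccc(OC)cc2)no1)C(F)(F)F`: in a functional assay on MCF7 cells (Homo sapiens) for inhibition, read by MTT assay, with a stated time of 24 h (a higher number here means a weaker inhibitor, a lower number a stronger inhibitor), compound 1 gives > 150000 nM, which is a limit of the assay and not a number.
Compound 2 `CCOC(=O)C1=Cc2ccccc2OC1(OCc1cc(-c2ccc3ccccc3c2)no1)C(F)(F)F`: compound 2 gives 65400 nM.
Compound 3 `CCOC(=O)C1=Cc2ccccc2OC1(OCc1cc(-c2ccc([N+](=O)[O-])cc2)no1)C(F)(F)F`: compound 3 gives > 150000 nM, again a limit of the assay.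

Compound 1 thus stands at the limit of this assay, a position it shares with compound 3 (the limit of > 150000 nM in this assay, at which 2 of the 3 values shown sit). Only compound 2 returns a number, so an at least 2.2-fold lower number from compound 1 to compound 2 (0.36 log units; beyond the scatter) and an at least 2.2-fold higher number from compound 2 to compound 3 (0.36 log units; beyond the scatter) are both at least modest, while a step that the two limits leave unreadable from compound 1 to compound 3 cannot be read at all.

Compound 4 `COc1ccc(-c2cc(COC3(C(F)(F)F)Oc4ccccc4C=C3C(=O)O)on2)cc1` differs from compound 1 only by hydrogen in place of ethyl on an oxygen next to a carbonyl group. None of the three measured steps touches this part of the molecule; all of them alter a group elsewhere. No direction or size for the step can therefore be taken from them.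

Since compound 1 already sits at the limit, compound 4 is expected to give 150000 nM, with a range from 50000 nM to 500000 nM. The step of a number no higher from compound 1 to compound 4 (the limit leaves the size open) is expected to leave compound 4 at or near the limit as well.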

Compound 4, half-maximal inhibitory concentration: 35200 nM
Beside the measured number, compound 4's estimate is 4.3-fold (0.63 log units) above it, and the stated range ends above it.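

In this assay, among the compounds shown here, hydrogen in place of ethyl on an oxygen next to a carbonyl group gives an at least 4.2-fold lower number from compound 1 to compound 4 (0.62 log units; beyond the scatter), so this position, which no earlier step touched, can also move the read-out. Compound 1 gives > 150000 nM, which is a limit of the assay and not a number, so the step has a lower bound and no upper one. The ethoxy to hydroxy change alone takes the 4-methoxyphenyl compound off a limit that remains common in this small set: the limit of > 150000 nM in this assay, at which 2 of the 4 values shown sit.

The compounds shown leave open whether a methyl ester or a primary amide at this place would behave like the ethyl ester or like the acid. They also leave open whether the same cut would lower the number for the naphthalen-2-yl or the 4-nitrophenyl compound.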